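This account rests on a few compounds, and the source may have more. Where it says the series, first, only, none or still open, it means among the compounds named here.

Compound 1 `CN1CCC(NC(=O)Nc2cccc3[nH]ncc23)c2ccccc21` — 215 nM
Compound 2 `CN1CCC(NC(=O)Nc2cccc3[nH]ncc23)c2ccc(F)cc21` — 34 nM

For the measured compounds named here, in a functional assay for antagonist activity at transient receptor potential cation channel subfamily V member 1 (Homo sapiens), read by calcium flux (on this read-out lower numbers stand for stronger inhibition and higher numbers for weaker inhibition), compound 1 gives 215 nM, the higher of the two numbers measured so far; its only neighbour is compound 2, reached by a 6.3-fold lower number from compound 1 to compound 2 (0.80 log units; beyond the scatter). Compound 3 `CN1CCC(NC(=O)Nc2cccc3[nH]ncc23)c2cc(C(C)(C)C)ccc21` has not yet been measured. It differs from compound 1 by tert-butyl in place of hydrogen on an aromatic carbon. Going by the values given here, the single measured step bears on this only loosely: it also added a group to an aromatic carbon of the shared core and lowered the number, but the group entering compound 3 differs in kind and sits in a different place, and no measured compound carries a tert-butyl group. The expectation is therefore a step of about a 1.1-fold lower number from compound 1 to compound 3 (0.03 log units; within the scatter), with wide uncertainty in either direction. Compound 3 is estimated at 200 nM, within a range from 50 nM to 800 nM.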

Compound 3, half-maximal inhibitory concentration: 853 nM
For compound 3 the middle estimate is 4.3-fold (0.63 log units) below the measured one, outside the stated range (above it).
By their numbers in this assay, from the lowest: compound 2; then compound 1; then compound 3.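

Placing tert-butyl on this aromatic carbon gives, in this assay, a 4.0-fold higher number from compound 1 to compound 3 (0.60 log units; beyond the scatter) and so moves the number the opposite way to the only earlier step. Adding a group to this ring of the shared core therefore does not lower the number as a general rule: fluoro gave a 6.3-fold lower number from compound 1 to compound 2 (0.80 log units; beyond the scatter), but that step differs from this one in both the group and the carbon it sits on. Nothing measured here says why the number rose.

Still open, from the compounds shown here alone, is how methyl, methoxy, an amine or a carboxylic acid on this same carbon would compare with tert-butyl. Also open, going by these compounds, is how fluoro on this carbon, or tert-butyl on the carbon bearing fluoro in compound 2, would behave, which would separate the role of the group from that of its place.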